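Ethoxy to Methyl Where Every Value Is a Limit

This account rests on a few compounds, and the source may have more. Where it says the series, first, only, none or still open, it means among the compounds named here.

Compound 3 `CCOc1ccc(C(=O)Nc2cc3nc(C4CCCCC4)[nH]c3cc2N(CC)CC)cc1` was examined in an ADME assay on Vero cells (Chlorocebus sabaeus) for cytotoxicity, read by resazurin assay, with a stated time of 3 days; on this read-out lower numbers stand for stronger inhibition and higher numbers for weaker inhibition. In this assay compound 3 gives > 100 ug/mL, which is a limit of the assay rather than a number. Its two relatives sit at the same limit (the limit of > 100 ug/mL in this assay, at which 3 of the 3 values shown sit). Compound 1 `CCN(CC)c1cc2[nH]c(C3CCCCC3)nc2cc1NC(=O)c1ccc(OC(F)F)cc1` gives > 100 ug/mL, a limit. Compound 2 `CCCC(C)OC(=O)Nc1cc2nc(C3CCCCC3)[nH]c2cc1N(CC)CC` gives > 100 ug/mL, also a limit. The steps among them, a step that the two limits leave unreadable from compound 1 to compound 2, a step that the two limits leave unreadable from compound 1 to compound 3 and a step that the two limits leave unreadable from compound 2 to compound 3, are therefore of unreadable size. Compound 4 `CCN(CC)c1cc2[nH]c(C3CCCCC3)nc2cc1NC(=O)c1ccc(C)cc1` is not yet measured; it differs from compound 3 by methyl in place of ethoxy on an aromatic carbon. Going by the values given here, no measured step bears on this change with a readable size, so no shift beyond the scatter is expected, and compound 4 is expected to stay at the limit, a step that the limit leaves unreadable from compound 3 to compound 4. Compound 4 is estimated at 120 ug/mL, between 60 ug/mL and 250 ug/mL.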

Compound 4, half-maximal inhibitory concentration: > 100 ug/mL
Compound 4 gave a limit, no number; the forecaster's own chance of this, stated with the estimate: 85%; the middle value does not contradict the limit.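

The steps from compound 4 to compound 1, compound 2 and compound 3 cannot be read, since all four compounds end at a limit: the limit of > 100 ug/mL in this assay, at which 4 of the 4 values shown sit.

Whether any of these groups changes cytotoxicity in this assay stays open, as no compound shown gives a number.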